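The compounds below may be only part of what the source reports. "The series", "measured", "known", "first", "only" and "open" are said of these compounds alone.

Measured compounds in an assay on CHO cells for displacement of a labelled ligand from prostaglandin E2 receptor EP1 subtype (Homo sapiens); a lower number here means a stronger inhibitor, a higher number a weaker inhibitor:
compound 1, `COc1ccc(Cc2nnc(CN(c3cccc(Cl)c3C)S(=O)(=O)c3ccc(C)cc3)o2)cc1`, gives 6.31 nM
compound 2, `Cc1ccc(S(=O)(=O)N(Cc2nnc(Cc3ccc(N(C)C)cc3)o2)c2cccc(Cl)c2C)cc1`, gives 12.6 nM
compound 3, `Cc1ccc(S(=O)(=O)N(Cc2nnc(Cc3ccccc3Cl)o2)c2cccc(Cl)c2C)cc1`, gives 79.4 nM

Compound 3 stands at the highest number of the three: a 13-fold higher number from compound 1 to compound 3 (1.10 log units; beyond the scatter) and a 6.3-fold higher number from compound 2 to compound 3 (0.80 log units; beyond the scatter) are both beyond the scatter, while compounds 1 and 2 lie within the scatter of each other (a 2.0-fold higher number from compound 1 to compound 2 (0.30 log units; within the scatter)). Compound 4, `Cc1ccc(S(=O)(=O)N(Cc2nnc(Cc3c(Cl)cccc3Cl)o2)c2cccc(Cl)c2C)cc1`, is not yet measured. It differs from compound 3 in one place: chloro in place of hydrogen on an aromatic carbon, so that 2-chlorobenzyl becomes 2,6-dichlorobenzyl. Going by the values given here, no measured step bears directly on this change. The steps that exist exchange the whole aryl group on the benzyl carbon, and they show that 2-chlorophenyl gives a clearly higher number than either 4-methoxyphenyl or 4-(dimethylamino)phenyl; they say nothing about a second chloro on the same ring. For this assay the expected step is therefore one not beyond the scatter in either direction, carrying wide uncertainty: the estimated step is a 1.0-fold higher number from compound 3 to compound 4 (0.00 log units; within the scatter). Compound 4 is expected to give about 80 nM, with a range from 25 nM to 250 nM.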

Compound 4, half-maximal inhibitory concentration: 63.1 nM
Beside the measured number, compound 4's estimate is 1.3-fold (0.10 log units) above it; measured number inside the range.
By their numbers in this assay, from the lowest: compounds 1 and 2 (each within the scatter of the next); then compounds 4 and 3 (each within the scatter of the next).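

In this assay, adding a second chloro to the ring, so that 2-chlorobenzyl becomes 2,6-dichlorobenzyl, leaves the number within the scatter (a 1.3-fold lower number from compound 3 to compound 4 (0.10 log units; within the scatter)). The gap to the 4-substituted benzyl compounds therefore remains, both for 4-methoxyphenyl (a 10-fold higher number from compound 1 to compound 4 (1.00 log units; beyond the scatter)) and for 4-(dimethylamino)phenyl (a 5.0-fold higher number from compound 2 to compound 4 (0.70 log units; beyond the scatter)), so both chloro-bearing compounds stay weaker than those two. No available evidence bears on the reason for these numbers.

The compounds shown leave open how an unsubstituted benzyl or a 4-chlorobenzyl group would read, so the effect of adding chloro at the 2-position cannot be separated from that of removing the 4-substituent. From the compounds shown here alone, whether a carboxylic acid or a primary amine at the 4-position would hold the lower numbers also remains open.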